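A sulfonyl group exchange on compound 3

A few compounds are considered here, and "the series" means these few. Any claim that something is new, unique, unknown or untested is made for them only; others in the source may bear on it.

Measured so far in a physicochemical assay for lipophilicity, using the shake flask method, in phosphate buffer, measured as octanol-water partition, at pH 7.4 (on this read-out lower numbers stand for lower lipophilicity and higher numbers for higher lipophilicity), are these compounds:
- compound 1 `CC(C)(C)OC(=O)N1C[C@@H]2C[C@H]1CN2c1ncc(OCc2ccc(S(C)(=O)=O)cc2)cn1` gives 2.8
- compound 2 `CC(C)(C)OC(=O)N1C[C@@H]2CC[C@H]1CN2c1ncc(OCc2ccc(S(C)(=O)=O)cc2)cn1` gives 3.4
- compound 3 `C[C@@H]1CN(C(=O)OC(C)(C)C)CCN1c1ncc(OCC2CCN(S(C)(=O)=O)CC2)cn1` gives 3.5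

Compound 3 (3.5) sits within the usual scatter of compound 2 (3.4). Compound 3 stands clear of compound 1 (2.8): the gap is larger than the usual scatter, with compound 1 the lower of the two. Compound 4 `C[C@@H]1CN(C(=O)OC(C)(C)C)CCN1c1ncc(OCc2ccc(S(C)(=O)=O)cc2F)cn1` has 2-fluoro-4-(methylsulfonyl)phenyl in place of 1-(methylsulfonyl)piperidin-4-yl on a saturated chain carbon bound to an oxygen on an aromatic ring and has not yet been measured. For the measured compounds named here, no measured pair differs in one place, so no direct step guides the expectation. Compound 2 (3.4) also carries a phenyl group bearing methylsulfonyl, on another core, and stands level with compound 3. A small rise, not beyond the usual scatter, is therefore expected in this assay (estimated step a number 0.10 log units higher from compound 3 to compound 4 (within the scatter)). For compound 4 the estimated value is 3.6 (expected range 3.2 to 4).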

Compound 4, distribution coefficient: 3.7
Compound 4: middle estimate off by 0.10 log units, on the low side; the range from low to high includes it.
By their numbers in this assay, from the lowest: compound 1; then compounds 2, 3 and 4 (each within the scatter of the next).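

For the compounds shown here, the one direct step available in this assay is a number 0.20 log units higher from compound 3 to compound 4 (within the scatter) for 2-fluoro-4-(methylsulfonyl)phenyl in place of 1-(methylsulfonyl)piperidin-4-yl on a saturated chain carbon bound to an oxygen on an aromatic ring. This place therefore takes either a six-membered non-aromatic ring with a hetero atom or an aromatic ring of carbon only, each bearing methylsulfonyl, without a step beyond the scatter on this read-out. Nothing shown explains this outcome. On these data alone, what 4-(methylsulfonyl)phenyl without the fluorine would give on the core of compound 3 stays open, as does an amine or a carboxylic acid in place of the methylsulfonyl group.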